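A few compounds are considered here, and "the series" means these few. Any claim that something is new, unique, unknown or untested is made for them only; others in the source may bear on it.

Compound 1 `COc1cccc(S(=O)(=O)/C=C/c2ccccn2)c1` and compound 3 `COc1ccc(S(=O)(=O)/C=C/c2ccccn2)cc1` are built from the same atoms joined differently; the difference between the two cores is not broken down here. In an ADME assay on BV-2 cells (Mus musculus) for cytotoxicity, with a stated time of 24 h, tested at 50 uM (a higher number here means a weaker effect of the compound at the concentration tested, a lower number a stronger effect), compound 1 gives 98.9%, and compound 3 gives 100%, two readings that lie within the scatter of each other.

Compound 2 `COc1cccc(S(=O)(=O)/C=C/c2ncccc2F)c1` arises from compound 1 by one change, (fluoro in place of hydrogen on an aromatic carbon). In this assay compound 2 gives 97.4%, so that the step of a number 1.5 percentage points lower from compound 1 to compound 2 (within the scatter) is one the measurement cannot distinguish from repetition.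

Going by the values given here, compound 4 `COc1ccc(S(=O)(=O)/C=C/c2ncccc2F)cc1` carries the same change on the core of compound 3, (fluoro in place of hydrogen on an aromatic carbon), and is the one compound not yet measured. Among the compounds with values here, since the single example of this change left the reading of compound 1 essentially untouched in a number 1.5 percentage points lower from compound 1 to compound 2 (within the scatter), the step from compound 3 to compound 4 is expected to be of the same small size, a number 1 percentage points lower from compound 3 to compound 4 (within the scatter). On that basis compound 4 is expected to give about 99% in this assay, most likely between 91% and 103%.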

Compound 4, a percentage reported as activity, at one concentration (the size of the read-out at that concentration, not a potency): 86.6%
The estimate for compound 4 lay 12.4 percentage points above the measured number, outside the stated range (below it).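

On the core of compound 3, fluoro in place of hydrogen on an aromatic carbon gives, in this assay, a number 13.4 percentage points lower from compound 3 to compound 4 (beyond the scatter), a modest step that the measurement does distinguish from repetition, whereas the same change on the core of compound 1 gives a number 1.5 percentage points lower from compound 1 to compound 2 (within the scatter). Set side by side, the two steps look unequal, yet the gap between them is no larger than two such steps can show by scatter alone: the same change on two cores in this assay, a number 1.5 percentage points lower (within the scatter) from compound 1 to compound 2 and a number 13.4 percentage points lower (beyond the scatter) from compound 3 to compound 4, 11.9 percentage points apart, within the scatter of two such steps

So the series does not show that the change acts differently on the two cores, nor does it establish that the change carries over unaltered, since it rests on only one pair of steps, only one of which stands clear of the scatter.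

The compounds shown leave open whether a chloro group, a methyl group or an amine on that same aromatic carbon would shift the reading as fluoro does on either core. They also leave open what a longer chain in place of the methoxy group would do to it.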